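This account rests on a few compounds, and the source may have more. Where it says the series, first, only, none or still open, it means among the compounds named here.

Compound 3 `CC(=O)/C(=N\c1ccccc1)NNc1ccccc1C(F)(F)F` gives 2260 nM in an assay on isolated protein for binding affinity to corticotropin-releasing factor receptor 1 (Homo sapiens) (on this read-out higher numbers stand for weaker inhibition and lower numbers for stronger inhibition), the highest of the two plain numbers in hand; compound 2 `CC(=O)/C(=N\c1ccccc1)NNc1ccccc1C` gives 526 nM, and the step of a 4.3-fold higher number from compound 2 to compound 3 (0.63 log units; beyond the scatter) lies beyond the scatter. Compound 1 `CC(=O)/C(=N\Nc1ccccc1Cl)Sc1cccc(Cl)c1` yields only a limit of this assay, > 10000 nM, as recorded in the limit of > 10000 nM in this assay, at which 1 of the 3 values shown sits. Compound 4 `CC(=O)/C(=N\c1cccc(C)c1)NNc1ccccc1C(F)(F)F` differs from compound 3 by methyl in place of hydrogen on an aromatic carbon. For the measured compounds named here, no measured step touches that ring: the single measured step, from compound 2 to compound 3, concerns a substituent on the other ring. This assay therefore offers no footing for a change beyond the scatter, and a small move either way remains possible. Compound 4 is accordingly estimated at 2000 nM, within 700 nM to 6000 nM, the expected step being a 1.1-fold lower number from compound 3 to compound 4 (0.05 log units; within the scatter).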

Compound 4, inhibition constant: 1420 nM
Estimate against measurement, compound 4: 1.4-fold (0.15 log units) above, within the range that was stated.
By their numbers in this assay, from the lowest: compound 2; then compounds 4 and 3 (each within the scatter of the next). At a limit, above all of these: compound 1.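

For the compounds shown here, the change from phenyl to 3-methylphenyl is the first measured on this ring, and in this assay it gives a 1.6-fold lower number from compound 3 to compound 4 (0.20 log units; within the scatter). A methyl at this place therefore moves the number by no more than the scatter can hide, unlike the substituent change on the other ring, a 4.3-fold higher number from compound 2 to compound 3 (0.63 log units; beyond the scatter). Nothing measured here gives a reason for this result.

Going by these compounds, whether a methoxy, a chlorine, an amine or a carboxylic acid at this place would behave the same stays open. So does whether this methyl would read the same alongside the methyl of compound 2 on the other ring.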